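This account rests on a few compounds, and the source may have more. Where it says the series, first, only, none or still open, it means among the compounds named here.

In a physicochemical assay for solubility, measured as kinetic solubility (a higher number here means a more soluble compound, a lower number a less soluble compound), compound 1 (`CCC/N=C1\S/C(=C\c2ccc(O)c(C#N)c2)C(=O)N1c1ccccc1C`) gives 220000 nM and compound 2 (`Cc1ccccc1N1C(=O)/C(=C/c2ccc(O)c(Cl)c2)S/C1=N\CCCF`) gives 20000 nM as the lower of the two numbers, and the gap between them lies beyond the usual scatter. Compound 3 (`COCC/N=C1\S/C(=C\c2ccc(O)c(Cl)c2)C(=O)N1c1ccccc1C`) has not yet been measured. It differs from compound 2 in one place, with methoxy in place of fluoromethyl on a saturated chain carbon, two bonds along the chain from a double-bonded nitrogen. Cut one bond further out, the same difference reads 3-fluoropropyl to 2-methoxyethyl. Among the measured compounds shown here, no two measured compounds differ in one place only, so no measured step speaks directly to this change. The expectation therefore starts from compound 2 at 20000 nM and remains uncertain. The expected change is a 2.0-fold higher number from compound 2 to compound 3 (0.30 log units; within the scatter) and is estimated as a modest rise, at about the edge of the usual scatter. For compound 3 the expected value in this assay is 40000 nM within an estimated range of 12000 nM to 130000 nM for this read-out.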

Compound 3, solubility: 110000 nM
Beside the measured number, compound 3's estimate is 2.8-fold (0.44 log units) below it; the measured number falls inside the stated range.
By their numbers in this assay, from the lowest: compound 2; then compounds 3 and 1 (each within the scatter of the next).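

In this assay, among the compounds shown here, methoxy in place of fluoromethyl on a saturated chain carbon, two bonds along the chain from a double-bonded nitrogen, gives a 5.5-fold higher number from compound 2 to compound 3 (0.74 log units; beyond the scatter), and this is the first step that changes one place only. The earlier compounds shown here differed in more than one place and could not isolate this position, whereas this pair shows that, with the rest of the structure held constant, exchanging 3-fluoropropyl for 2-methoxyethyl moves the number upward by more than the scatter. This is a single pair, however, and no accompanying measurement offers an explanation for the step.

On these data alone, it remains open what an amine, a hydroxyl group or a longer ether chain such as 3-methoxypropyl would give in this place, and whether a plain propyl chain would fall with compound 2 or with compound 3. Also open, as far as these compounds go, is whether the same exchange would produce a step of similar size and direction with the nitrile of compound 1 in place of the chlorine shared by compound 2 and compound 3.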